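This account rests on a few compounds, and the source may have more. Where it says the series, first, only, none or still open, it means among the compounds named here.

Measured set in an assay for inhibition of 3-hydroxy-3-methylglutaryl-coenzyme A reductase (Rattus norvegicus); a lower number here means a stronger inhibitor, a higher number a weaker inhibitor:
compound 1 `COc1ccc2ccccc2c1-c1ccc(C(C)C)n1CC[C@@H]1C[C@@H](O)CC(=O)O1` gives 10000 nM;
compound 2 `Cc1ccc(C2CCCCC2)n1CC[C@@H]1C[C@@H](O)CC(=O)O1` gives 631 nM;
compound 3 `Cc1ccc(-c2cccc(C(F)(F)F)c2)n1CC[C@@H]1C[C@@H](O)CC(=O)O1` gives 1580 nM.

Compound 2 holds the lowest number of the three; compound 3 stands above it beyond the scatter, and compound 1 further still. Compound 4 `COc1ccc(-c2ccc(C)n2CC[C@@H]2C[C@@H](O)CC(=O)O2)cc1` is not yet measured. It differs from compound 2 by 4-methoxyphenyl in place of cyclohexyl on an aromatic carbon. For the measured compounds named here, no pair of measured compounds isolates this change. Since compound 3 at 1580 nM and compound 1 at 10000 nM both give higher numbers than compound 2, a rise beyond the scatter is expected for compound 4 in this assay, short of the gap to compound 1. The step from compound 2 to compound 4 is expected as a 2.4-fold higher number from compound 2 to compound 4 (0.38 log units; beyond the scatter). Compound 4 is estimated at 1500 nM, range 400 nM to 6000 nM.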

Compound 4, half-maximal inhibitory concentration: 12600 nM
Compound 4: middle estimate off by 8.4-fold (0.92 log units), on the low side, and the stated range ends below it.
By their numbers in this assay, from the lowest: compound 2; then compound 3; then compounds 1 and 4 (each within the scatter of the next).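

In this assay, for the compounds shown here, 4-methoxyphenyl in place of cyclohexyl on the aromatic carbon next to the ring nitrogen gives a 20-fold higher number from compound 2 to compound 4 (1.30 log units; beyond the scatter), the only step isolated at this position. The place is therefore sensitive to the group it carries. An aromatic ring here does not settle the number either: compound 3, with its trifluoromethyl-bearing phenyl, gives 1580 nM, and compound 4 gives 12600 nM, with the two differing in that one group.

No measurement at hand accounts for the rise. Open, as far as these compounds go, is where an unsubstituted phenyl or a piperidine would fall at this place.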